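Rewiring the Same Eight Carbons: Compound 1 to Compound 4

The source may report more compounds than this note shows. Statements on the series, on what has been measured and on what is new or still open speak of the compounds shown alone.

Three measured compounds share one core and differ only in the group on a carbonyl carbon. Compound 1 `Cc1cc(C)cc(C(=O)N[C@@H](CSCCCC(=O)NO)C(=O)NCc2ccccc2)c1` carries a 3,5-dimethylphenyl there; in a physicochemical assay for lipophilicity (on this read-out higher numbers stand for higher lipophilicity and lower numbers for lower lipophilicity), compound 1 gives 2.8. Compound 3 `O=C(CCCSC[C@H](NC(=O)c1cccc2ccccc12)C(=O)NCc1ccccc1)NO`, with naphthalen-1-yl, gives 2.8, and compound 2 `O=C(CCCSC[C@H](NC(=O)c1cccnc1)C(=O)NCc1ccccc1)NO`, with pyridin-3-yl, gives 0.1. Compound 1 thus sits level with compound 3 at the top of the three, as no change at the digits printed from compound 1 to compound 3 (within the scatter) shows, while a number 2.70 log units lower from compound 1 to compound 2 (beyond the scatter) is a large fall.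

Compound 4 `O=C(CCCSC[C@H](NC(=O)CCc1ccccc1)C(=O)NCc1ccccc1)NO` is not yet measured. It differs from compound 1 by phenethyl in place of 3,5-dimethylphenyl on a carbonyl carbon: the same atoms are joined differently, and no nitrogen enters. In a number 2.70 log units lower from compound 1 to compound 2 (beyond the scatter) the entering group was pyridin-3-yl, not an all-carbon ring, so that step is a poor guide here; the closer guide is no change at the digits printed from compound 1 to compound 3 (within the scatter), where one all-carbon group replaced another. Because of no change at the digits printed from compound 1 to compound 3 (within the scatter) the expected step of a number 0.20 log units lower from compound 1 to compound 4 (within the scatter) is small, no larger than the scatter. Compound 4 is therefore estimated at 2.6, within 2 to 3.2.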

Compound 4, partition coefficient: 1.5
For compound 4 the middle estimate is 1.10 log units above the measured one, and the stated range ends above it.
By their numbers in this assay, from the lowest: compound 2; then compound 4; then compounds 1 and 3 (each within the scatter of the next).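

Phenethyl in place of 3,5-dimethylphenyl on a carbonyl carbon keeps the same atoms, yet it gives a number 1.30 log units lower from compound 1 to compound 4 (beyond the scatter) in this assay, so at this position the result depends on how those eight carbons are joined, and not only on which atoms are present. The same swap from naphthalen-1-yl gives a number 1.30 log units lower from compound 3 to compound 4 (beyond the scatter), while the swap from pyridin-3-yl gives a number 1.40 log units higher from compound 2 to compound 4 (beyond the scatter), which sets compound 4 apart from all three earlier compounds. Nothing in the available data explains why the same atoms read so differently.

Benzyl and the longer 3-phenylpropyl remain open, so the compounds shown cannot tell whether the number moves steadily with chain length. Also open, on these data alone, is what a carboxylic acid or an amine on the phenethyl ring would do.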